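The source may report more compounds than this note shows. Statements on the series, on what has been measured and on what is new or still open speak of the compounds shown alone.

Measured compounds:
Compound 1 `COc1ccc(-c2cc3[nH]nc(N)c3c(=O)[nH]2)cc1` in an assay on isolated protein for inhibition of ribosomal protein S6 kinase alpha-1 (Homo sapiens), read by mobility shift assay, tested at 30 uM (on this read-out higher numbers stand for more inhibition at the one concentration tested (going by the name of the read-out) and lower numbers for less inhibition), gives 7%.
Compound 2 `Cc1cc2[nH]nc(N)c2c(N2CCCCC2)n1` in this assay gives 46%.
Compound 3 `COc1ccc(-c2cc3c(c(N)nn3C)c(=O)[nH]2)cc1` in this assay gives 18%.

Compound 1 and compound 3 differ in one place, namely (methyl in place of hydrogen on an aromatic nitrogen). This change made a step of a number 11 percentage points higher from compound 1 to compound 3 (beyond the scatter), so the methylated compound read higher. Compound 2 is built on a different core; how the cores of compound 1 and compound 2 differ is not broken down here. In this assay compound 2 stands highest of the three, beyond the scatter from both compound 1 and compound 3.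

Compound 4 `Cc1cc2c(c(N)nn2C)c(N2CCCCC2)n1` is not yet measured. It differs from compound 2 by methyl in place of hydrogen on an aromatic nitrogen, the same change that was made from compound 1 to compound 3. Since the earlier step of a number 11 percentage points higher from compound 1 to compound 3 (beyond the scatter) was modest, the estimate for the step from compound 2 to compound 4 is a number 10 percentage points higher from compound 2 to compound 4 (within the scatter), of a similar size and the same direction. On that basis compound 4 is expected to give about 56% in this assay, with the estimate likely to fall between 36% and 74%.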

Compound 4, a percentage reported as inhibition, at one concentration (the size of the read-out at that concentration, not a potency): 23%
The estimate for compound 4 lay 33 percentage points above the measured number; measured number below the stated range.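

In this assay methyl in place of hydrogen on an aromatic nitrogen gave a number 23 percentage points lower from compound 2 to compound 4 (beyond the scatter) and so did not repeat the direction the same change had taken on the core of compound 1. Set side by side, the two steps differ: the same change on two cores in this assay, a number 11 percentage points higher (beyond the scatter) from compound 1 to compound 3 and a number 23 percentage points lower (beyond the scatter) from compound 2 to compound 4, 34 percentage points apart, beyond the scatter of two such steps.
This shows that, across these two pairs, a step read on one core could not simply be carried over to the other, but it does not show which difference between the cores goes with the reversal, and two pairs give no rule for any further core.

The compounds shown leave open whether an ethyl group or a longer chain on that aromatic nitrogen would follow either of the two steps. They also leave open how the same change from hydrogen to methyl would read on a core that carries a carboxylic acid.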